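A few compounds are considered here, and "the series" means these few. Any claim that something is new, unique, unknown or untested is made for them only; others in the source may bear on it.

Three compounds share one core and differ only in the substituted phenyl on the carbon with a double bond to nitrogen. In a functional assay on SW-620 cells (Homo sapiens) for cytotoxicity, read by sulforhodamine B assay, with a stated time of 48 h (a lower number here means a stronger inhibitor, a higher number a weaker inhibitor), compound 1 `C[C@H]1CC[C@@H]2[C@@H](OC(=O)[C@]23CC(c2c(Cl)cccc2Cl)=NO3)[C@]2(C)C(=O)C=C[C@@]12O` gives 43000 nM, compound 2 `C[C@H]1CC[C@@H]2[C@@H](OC(=O)[C@]23CC(c2ccc([N+](=O)[O-])cc2)=NO3)[C@]2(C)C(=O)C=C[C@@]12O` gives 9000 nM and compound 3 `C[C@H]1CC[C@@H]2[C@@H](OC(=O)[C@]23CC(c2cccc([N+](=O)[O-])c2)=NO3)[C@]2(C)C(=O)C=C[C@@]12O` gives 49000 nM. That puts the 3-nitrophenyl compound at the weak end of the set. Going by the values given here, the gap to its nearest neighbour is a 1.1-fold higher number from compound 1 to compound 3 (0.06 log units; within the scatter), and the gap to the one clearly stronger compound is a 5.4-fold higher number from compound 2 to compound 3 (0.74 log units; beyond the scatter).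

The next compound, compound 4 `Cc1cccc(C2=NO[C@]3(C2)C(=O)O[C@@H]2[C@H]3CC[C@H](C)[C@]3(O)C=CC(=O)[C@@]23C)c1`, changes a single group: methyl in place of nitro on an aromatic carbon. This is methyl in place of nitro on an aromatic carbon, meta to a large group, so 3-nitrophenyl becomes 3-methylphenyl.

Among the compounds with values here, no measured step makes this exact swap. The closest evidence comes from the other changes on the same phenyl. Two were modest, a 4.8-fold lower number from compound 1 to compound 2 (0.68 log units; beyond the scatter) and a 5.4-fold higher number from compound 2 to compound 3 (0.74 log units; beyond the scatter), and one stayed within the scatter, a 1.1-fold higher number from compound 1 to compound 3 (0.06 log units; within the scatter). A step of modest size is therefore the largest expected in this assay, with none beyond the scatter the likeliest outcome, and these data give no firm direction.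

For compound 4 the estimated value is 30000 nM, with an expected range of 10000 nM to 80000 nM. The expected change is a 1.6-fold lower number from compound 3 to compound 4 (0.21 log units; within the scatter).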

Compound 4, half-maximal inhibitory concentration: 15000 nM
Estimate against measurement, compound 4: 2.0-fold (0.30 log units) above; low and high end bracket the measured number.
By their numbers in this assay, from the lowest: compounds 2 and 4 (each within the scatter of the next); then compounds 1 and 3 (each within the scatter of the next).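

Keeping the substituent on the same aromatic carbon and changing only the group there gives a 3.3-fold lower number from compound 3 to compound 4 (0.51 log units; beyond the scatter) in this assay, so what sits at this place matters on its own, whereas the earlier steps replaced or moved a whole substitution pattern. A nitro group is also not required for the stronger end of this small set: the step of a 1.7-fold higher number from compound 2 to compound 4 (0.22 log units; within the scatter) stays within the scatter, so the 3-methylphenyl and 4-nitrophenyl compounds cannot be told apart here. The step of a 2.9-fold lower number from compound 1 to compound 4 (0.46 log units; beyond the scatter) lies beyond the scatter, which separates the 3-methylphenyl compound from the 2,6-dichlorophenyl compound, a separation that the 3-nitrophenyl compound did not achieve.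

Nothing shown here explains why the methyl and nitro compounds differ. As far as these compounds go, whether an amine, a carboxylic acid or a longer chain on this same aromatic carbon would keep the number of compound 4, or move it in either direction, remains open.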